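Bromo for chloro on the ethoxy-bearing ring

The source may report more compounds than this note shows. Statements on the series, on what has been measured and on what is new or still open speak of the compounds shown alone.

The series shares the core of compound 1 `CCOc1ccc(F)cc1C(C)NC(=O)NS(=O)(=O)c1ccc(C)cc1`. In a functional assay on thoracic aorta (Rattus norvegicus, strain Wistar), with a stated time of 15 min (a lower number here means that less compound is needed, a higher number that more compound is needed for the effect), compound 1 gives only a limit of the assay, > 300000 nM. Compound 3 `CCOc1ccc(Cl)cc1C(C)NC(=O)NS(=O)(=O)c1ccc(C)cc1` likewise gives only a limit in this assay, > 300000 nM. The step that the two limits leave unreadable from compound 1 to compound 3, chloro in place of fluoro on an aromatic carbon, is therefore not readable. For the measured compounds named here, compound 2 `Cc1ccc(S(=O)(=O)NC(=O)NC(C)c2cc(Br)ccc2OCc2ccccc2)cc1`, with a different ether and a bromo group, gives 138000 nM in this assay, the one numeric value of the three, but it differs from the others in two places, so no single step is drawn from it. Compound 3 thus stands at a limit, as does compound 1, which is the one fixed point of the set: the limit of > 300000 nM in this assay, at which 2 of the 3 values shown sit.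

Compound 4 `CCOc1ccc(Br)cc1C(C)NC(=O)NS(=O)(=O)c1ccc(C)cc1` is not yet measured. It differs from compound 3 by bromo in place of chloro on an aromatic carbon. Going by the values given here, the single measured step with a similar halogen change is unreadable, and compound 2 cannot be tied to compound 4 by one change, so no direction is readable. Compound 4 is expected to remain at or near the limit, with an estimate of about 250000 nM in this assay, between 60000 nM and 1000000 nM, and a fair chance that only a limit is reported. The estimated step of an at least 1.2-fold lower number from compound 3 to compound 4 (0.07 log units; that floor lies within the scatter) is thus expected to lie within the scatter.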

Compound 4, half-maximal effective concentration: > 300000 nM
Compound 4: a limit, no number; the forecaster's own chance of this, stated with the estimate: 65%; at least 1.2-fold (0.07 log units) between middle value and limit.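

With bromo now shared, compound 2 is tied to the series by a single change, and that change lies at the ether, not at the halogen: in this assay, methyl in place of phenyl on a saturated chain carbon bound to an oxygen on an aromatic ring is an at least 2.1-fold higher number from compound 2 to compound 4 (0.33 log units; beyond the scatter). The steps among the fluoro, chloro and bromo compounds with the ethoxy group cannot be read, so the halogen position shows no direction. All three ethoxy compounds stay at a limit, not a number: the limit of > 300000 nM in this assay, at which 3 of the 4 values shown sit.

As far as these compounds go, whether the halogen matters once the phenyl is kept on the ether stays open, since only bromo appears with it. Also open, from the compounds shown here alone, is how a propoxy ether, or an amine in place of the halogen, would read in this assay.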